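The compounds below may be only part of what the source reports. "The series", "measured", "known", "first", "only" and "open" are said of these compounds alone.

Compound 1 `CC(C(=O)NCc1ccc(C(F)(F)F)nc1N(C)c1ccccc1)c1ccc(NS(C)(=O)=O)c(F)c1`, compound 2 `CC(C(=O)NCc1ccc(C(F)(F)F)nc1N1CC=CCC1)c1ccc(NS(C)(=O)=O)c(F)c1` and compound 3 `CC(C)OC1CCN(c2nc(C(F)(F)F)ccc2CNC(=O)C(C)c2ccc(NS(C)(=O)=O)c(F)c2)CC1` share one core and differ only in the group carried on the aromatic carbon of the core. In a functional assay on CHO-K1 cells for antagonist activity at transient receptor potential cation channel subfamily V member 1 (Homo sapiens), read by FLIPR (a lower number here means a stronger inhibitor, a higher number a weaker inhibitor), compound 1 gives 0.9 nM, compound 2 gives 0.3 nM and compound 3 gives 3 nM, so compound 3 stands highest of the three, with compound 1 nearest and compound 2 furthest from it. The steps run a 3.0-fold lower number from compound 1 to compound 2 (0.48 log units; beyond the scatter), a 3.3-fold higher number from compound 1 to compound 3 (0.52 log units; beyond the scatter) and a 10-fold higher number from compound 2 to compound 3 (1.00 log units; beyond the scatter).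

Compound 4 `CC(C(=O)NCc1ccc(C(F)(F)F)nc1N1CCCCCCC1)c1ccc(NS(C)(=O)=O)c(F)c1` takes the change (a group of 8 heavy atoms (7 carbon, 1 nitrogen; one eight-membered non-aromatic ring with 1 hetero atom) in place of a group of 10 heavy atoms (8 carbon, 1 nitrogen, 1 oxygen; one six-membered non-aromatic ring with 1 hetero atom), on an aromatic carbon). The step bearing most on it is a 10-fold higher number from compound 2 to compound 3 (1.00 log units; beyond the scatter), where the six-membered non-aromatic ring with one hetero atom and no oxygen gave the lowest number of the set; the step of a 3.3-fold higher number from compound 1 to compound 3 (0.52 log units; beyond the scatter) points the same way. Compound 4 again carries a ring with one hetero atom and no oxygen, now eight-membered, and a number below that of compound 3 is therefore expected, most likely toward compound 2, giving an expected step of a 3.8-fold lower number from compound 3 to compound 4 (0.57 log units; beyond the scatter). The estimate for compound 4 in this assay is 0.8 nM, within 0.2 nM to 3 nM.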

Compound 4, inhibition constant: 0.7 nM
For compound 4 the middle estimate is 1.1-fold (0.06 log units) above the measured one; the range from low to high includes it.
By their numbers in this assay, from the lowest: compound 2; then compounds 4 and 1 (each within the scatter of the next); then compound 3.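

Across the four groups on this aromatic carbon next to the ring nitrogen, the number follows the heavy-atom count in this assay: the eight-membered ring gives a 4.3-fold lower number from compound 3 to compound 4 (0.63 log units; beyond the scatter), yet still shows a 2.3-fold higher number from compound 2 to compound 4 (0.37 log units; beyond the scatter), so it falls between compound 3 and compound 2. A non-aromatic ring and an open methyl(phenyl)amino group of equal heavy-atom count also read alike, with a 1.3-fold lower number from compound 1 to compound 4 (0.11 log units; within the scatter), so in this pair neither the ring type nor the ring closure separates the two. Nothing on hand gives a cause for these steps.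

Compound 3 alone carries oxygen, so its heavy-atom count and its oxygen remain confounded; unsubstituted piperidin-1-yl or 4-methoxypiperidin-1-yl would pull them apart. Compound 2 also differs from compound 4 by its ring double bond, and a saturated seven-membered azepan-1-yl ring would help place that difference.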